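Chloro for bromo: one halogen exchange in the series

The source may report more compounds than this note shows. Statements on the series, on what has been measured and on what is new or still open speak of the compounds shown alone.

Of the compounds shown here, three have been measured so far. Compound 1 `CNC(=O)c1ccc(Sc2ccc(NC(=S)Nc3cccc(C)c3)cc2)nc1` gives 52400 nM in a functional assay on HCT-116 cells (Homo sapiens) for cytotoxicity, read by MTT assay, with a stated time of 48 h; on this read-out lower numbers stand for stronger inhibition and higher numbers for weaker inhibition. Compound 2 `CNC(=O)c1ccc(Sc2cccc(NC(=S)Nc3ccc(F)c(F)c3)c2)nc1` gives 35100 nM in this assay. Compound 3 `CNC(=O)c1ccc(Sc2cccc(NC(=S)Nc3ccc(Br)c(C(F)(F)F)c3)c2)nc1` gives 16500 nM in this assay, the lowest of the three numbers: its gap to compound 2 lies beyond the scatter, and its gap to compound 1 is wider still. Among the measured compounds shown here, no pair of these three differs in only one place, so no single step between measured compounds can be isolated from them.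

Compound 4 `CNC(=O)c1ccc(Sc2cccc(NC(=S)Nc3ccc(Cl)c(C(F)(F)F)c3)c2)nc1` is the next compound. It differs from compound 3 in one place: chloro in place of bromo on an aromatic carbon. The exchange leaves heavy-atom count, donors, acceptors and charge unchanged, and the trifluoromethyl group and the large group keep their places. Nothing measured in the series speaks to this exchange directly. A swap of one halogen for another at the same aromatic carbon is expected to move the number little, so the step of a 1.2-fold higher number from compound 3 to compound 4 (0.08 log units; within the scatter) is expected to fall within the scatter or only just outside it, if anything toward a slightly weaker effect. Compound 4 is therefore estimated at 20000 nM, with a range from 8000 nM to 50000 nM.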

Compound 4, half-maximal inhibitory concentration: 5180 nM
Beside the measured number, compound 4's estimate is 3.9-fold (0.59 log units) above it, and the stated range ends above it.
By their numbers in this assay, from the lowest: compound 4; then compound 3; then compounds 2 and 1 (each within the scatter of the next).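

The aromatic carbon ortho to a trifluoromethyl group and para to a large group responds to the halogen it carries in this assay and chloro in place of bromo there gives a 3.2-fold lower number from compound 3 to compound 4 (0.50 log units; beyond the scatter) while heavy-atom count, hydrogen-bond donors, hydrogen-bond acceptors and net charge all stay the same. Among the compounds shown here, this is the first change that can be read at a single place, as compounds 1, 2 and 3 differ from one another in more than one place, and it shows that exchanging one halogen at this carbon is enough to move the number beyond the scatter. Nothing measured here accounts for the size or direction of this step.

With only bromo and chloro compared at this carbon, the compounds shown leave open how hydrogen, methyl, methoxy or a nitrile would read there, and so whether the lower number is specific to chloro. Also open, as far as these compounds go, is whether the same exchange gives a similar step when the neighbouring trifluoromethyl group is replaced by a nitrile or when the thiourea is replaced by a urea.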